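Swapping tert-butyl for cyclopropyl on an ether oxygen

The source may report more compounds than this note shows. Statements on the series, on what has been measured and on what is new or still open speak of the compounds shown alone.

Going by the values given here, compound 1 `COc1cn2ncc(-c3ccnc(OC(C)(C)C)c3)c2nc1-c1cnn(C)c1` is one of three compounds measured in an ADME assay on microsomes from liver (Homo sapiens) for metabolic stability, with a stated time of 60 min, tested at 1 uM; a lower number here means that less of the compound is left, a higher number that more of the compound is left. In this assay compound 1 gives 35%, which places it second highest among the three. Compound 2 `COc1cc(-c2cnn3cc(OC)c(C(C)(C)O)nc23)ccn1` gives 66% and stands highest. Compound 3 `COc1cc(-c2cnn3cc(OC)c([C@H]4COC(C)(C)C4)nc23)ccn1` gives 21%, the lowest of the three. Among the compounds with values here, the only step between measured compounds that differ in one place runs from compound 2 to compound 3: a number 45 percentage points lower from compound 2 to compound 3 (beyond the scatter). That change sits on another part of the shared core and does not touch the group that differs between compound 1 and compound 4.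

Compound 4 `COc1cn2ncc(-c3ccnc(OC4CC4)c3)c2nc1-c1cnn(C)c1` is not yet measured. It differs from compound 1 in one place: cyclopropyl in place of tert-butyl on an oxygen on an aromatic ring. Within the data shown here, no measured pair shows this exchange, so there is no step to lean on; the step from compound 2 to compound 3 concerns a different group at a different place. With nothing to set the direction, the expected step from compound 1 to compound 4 is a number 5 percentage points higher from compound 1 to compound 4 (within the scatter), within the scatter. Compound 4 is therefore estimated at 40% in this assay, with a range from 20% to 65%.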

Compound 4, percent of the compound remaining: 47%
Compound 4: middle estimate off by 7 percentage points, on the low side; measured number inside the range.
By their numbers in this assay, from the lowest: compound 3; then compound 1; then compound 4; then compound 2.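

In this assay, going by these compounds alone, the exchange of tert-butyl for cyclopropyl on an oxygen on an aromatic ring gives a number 12 percentage points higher from compound 1 to compound 4 (beyond the scatter) as the first direct reading at this position. The group on this oxygen therefore affects how much compound is left, and of these two groups, cyclopropyl leaves more. No measurement at hand explains why the number moves.

On these data alone, these two groups differ both in their carbon count and in the three-membered ring, so it stays open which of the two differences matters, if either does alone. As far as these compounds go, a methyl, an ethyl or a trifluoroethyl group on the same oxygen could help to separate these effects, and whether the exchange would give a similar step on a different core also remains unknown.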